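The source may hold more compounds than are shown below. What is called first, only, known or untested is meant among the compounds shown, and "the series" means these compounds.

Compound 1 `Cc1nnc(Sc2cc(NC(=O)c3ccc(Cl)cc3)c3ccccc3c2O)s1` bears a 5-methyl-1,3,4-thiadiazol-2-yl on a sulfur. In a functional assay on MDA-MB-231 cells (Homo sapiens) for antiproliferative activity, read by MTT assay, with a stated time of 48 h (a higher number here means a weaker inhibitor, a lower number a stronger inhibitor), compound 1 reaches only a limit, > 100000 nM. Compound 2 `O=C(Nc1cc(Sc2ncn[nH]2)c(O)c2ccccc12)c1ccc(Cl)cc1` bears a 1H-1,2,4-triazol-5-yl there instead, and in this assay compound 2 gives 25700 nM, the only full number shown. For the measured compounds named here, the single measured step is an at least 3.8-fold lower number from compound 1 to compound 2 (0.59 log units; beyond the scatter), the sole evidence for swapping this ring. Compound 3 `Cn1nnnc1Sc1cc(NC(=O)c2ccc(Cl)cc2)c2ccccc2c1O` swaps it again: 1-methyl-1H-tetrazol-5-yl in place of 1H-1,2,4-triazol-5-yl on a sulfur. Because compound 1, also without a hydrogen-bond donor on its ring, stayed at the limit > 100000 nM, compound 3 is expected to be weaker, with a step of a 2.3-fold higher number from compound 2 to compound 3 (0.37 log units; beyond the scatter). Compound 3 is estimated at 60000 nM, between 20000 nM and 150000 nM.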

Compound 3, half-maximal inhibitory concentration: > 100000 nM
Compound 3 gave a limit, no number (the forecaster's own chance of this, stated with the estimate: 40%); middle value at least 1.6-fold (0.22 log units) from the limit.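

In this assay, the change to 1-methyl-1H-tetrazol-5-yl on a sulfur gives an at least 3.8-fold higher number from compound 2 to compound 3 (0.59 log units; beyond the scatter). This is a second ring with 0 hydrogen-bond donors that yields no full number, whereas the 1H-1,2,4-triazol-5-yl of compound 2, with its 1 donor, does. The step between compound 1 and compound 3 cannot be read, and compound 2 alone gives a full number: the limit of > 100000 nM in this assay, at which 2 of the 3 values shown sit.

The link to the donor therefore rests on a single compound. Going by these compounds, how an unmethylated 1H-tetrazol-5-yl, or a triazole ring carrying an amine, would behave remains open.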